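Replacing one group on compound 1: an expected outcome

The compounds below may be only part of what the source reports. "The series", "measured", "known", "first", "only" and "open" are said of these compounds alone.

Measured compounds:
compound 1 `Cc1c(-n2c(-c3ccccc3)c(-c3ccccc3)c3c(Nc4ccccc4)ncnc32)n(C)n(-c2ccccc2)c1=O` — 27.9%
compound 2 `Cc1nc2c(c(-c3ccccc3)c(-c3ccccc3)n2-c2c(C)c(=O)n(-c3ccccc3)n2C)c(=O)[nH]1` — 27.7%
compound 3 `Cc1c(-n2c(N)c(C(N)=O)c(-c3ccccc3)c2-c2ccccc2)n(C)n(-c2ccccc2)c1=O` — 62.6%

All three were tested in a functional assay on the whole organism (strain Sprague-Dawley) for inhibition, with Rattus norvegicus as the target, read by paw edema, with stated times of 1 h and 4 h, at a dose of 70 mg/kg by the subcutaneous route; on this read-out higher numbers stand for more inhibition at the one dose given (going by the name of the read-out) and lower numbers for less inhibition. Compound 1 gives the second highest of the three numbers; compound 2 lies within the scatter of it, so no order between the two can be read, while compound 3 stands beyond the scatter above compound 1. Compound 4 `Cc1c(-n2c(-c3ccccc3)c(-c3ccccc3)c3c(N/N=C/c4ccccc4)ncnc32)n(C)n(-c2ccccc2)c1=O` differs from compound 1 in one place: a group of 8 heavy atoms (7 carbon, 1 nitrogen; one six-membered aromatic ring of carbon only) in place of a group of 6 heavy atoms (6 carbon; one six-membered aromatic ring of carbon only), on a nitrogen on an aromatic ring. Among the measured compounds shown here, no step between measured compounds involves this change, so nothing in the data ties it to a shift in inhibition. The expected step of a number 2.1 percentage points higher from compound 1 to compound 4 (within the scatter) is therefore small, in no set direction, and not beyond the scatter. Compound 4 is expected to give 30%, between 15% and 46%.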

Compound 4, a percentage reported as inhibition, in the whole organism at one dose (the size of the read-out at that dose, not a potency): 48.4%
Beside the measured number, compound 4's estimate is 18.4 percentage points below it; measured number above the stated range.
By their numbers in this assay, from the lowest: compounds 2 and 1 (each within the scatter of the next); then compound 4; then compound 3.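

In this assay, putting the group of 8 heavy atoms in place of phenyl, on a nitrogen on an aromatic ring, gives a number 20.5 percentage points higher from compound 1 to compound 4 (beyond the scatter) and adds a double bond outside aromatic rings and a hydrogen-bond acceptor. This first step at this place shows that the read-out responds to the group carried there. Nothing available explains the shift.

This single step cannot separate the added nitrogen from the double bond. From the compounds shown here alone, how a benzyl group or a plain amino group would read at this place remains open.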